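Trifluoromethoxy to Chloro: One Change, One Open Value

The compounds below may be only part of what the source reports. "The series", "measured", "known", "first", "only" and "open" are said of these compounds alone.

Compound 1 `Cc1cc(Nc2ccc(C(=O)/C=C/c3ccc(OC(F)(F)F)cc3)cc2)n2nc(SCc3nc4ccccc4[nH]3)nc2n1`: 220 nM
Compound 2 `Cc1cc(Nc2ccc(C(=O)/C=C/c3ccc4ccccc4c3)cc2)n2nc(SCc3cccc4ccccc34)nc2n1`: 68 nM

Among the compounds with values here, in a functional assay on SW-620 cells (Homo sapiens) for cytotoxicity, read by MTT assay, with stated times of 4 h and 72 h, tested at 2 uM (on this read-out higher numbers stand for weaker inhibition and lower numbers for stronger inhibition), compound 1 gives 220 nM, the higher of the two numbers measured so far and so the weaker inhibition. Compound 2 gives 68 nM, a lower number by more than the usual scatter. These two compounds differ in more than one place, so their gap says nothing about any single change.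

Compound 3 `Cc1cc(Nc2ccc(C(=O)/C=C/c3ccc(Cl)cc3)cc2)n2nc(SCc3nc4ccccc4[nH]3)nc2n1` has not yet been measured. It departs from compound 1 in one place: chloro in place of trifluoromethoxy on an aromatic carbon. This puts chloro in place of trifluoromethoxy on an aromatic carbon, para to a large group.

Within the data shown here, no measured pair of compounds isolates a change of this kind, so the data give no direct guide to it. With no evidence for a shift in either direction, no step beyond the scatter is expected in this assay. The expected change is a 1.1-fold lower number from compound 1 to compound 3 (0.04 log units; within the scatter).

For compound 3 the estimated value is 200 nM, with an expected range from 80 nM to 500 nM.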

Compound 3, half-maximal inhibitory concentration: 230 nM
The estimate for compound 3 lay 1.2-fold (0.06 log units) below the measured number; low and high end bracket the measured number.
By their numbers in this assay, from the lowest: compound 2; then compounds 1 and 3 (each within the scatter of the next).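

In this assay, within the data shown here, the exchange of 4-(trifluoromethoxy)phenyl for 4-chlorophenyl gives a 1.0-fold higher number from compound 1 to compound 3 (0.02 log units; within the scatter) and so supplies the first pair in this set that differs in one place only. On this aromatic carbon, para to a large group, five heavy atoms including one hydrogen-bond acceptor give way to a single chlorine, and the assay does not separate compound 1 from compound 3, at least for this one exchange on this core. Nothing measured here accounts for why these two groups read alike.

From the compounds shown here alone, whether a methoxy group, an amine or a carboxylic acid on the same carbon would also stay within the scatter of compound 1 remains open, as does the result of leaving that carbon with a plain hydrogen. Going by these compounds, it is also open whether chloro and trifluoromethoxy would read alike with different groups elsewhere on the core, and compound 2 cannot answer this, since it differs from compound 1 and compound 3 in more than one place.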